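A Methyl Step on a Core Where Every Value Is a Limit

The compounds below may be only part of what the source reports. "The series", "measured", "known", "first", "only" and "open" are said of these compounds alone.

Compound 1 `O=c1cc(CC(O)COCc2ccccc2)[nH]c(=O)[nH]1` was tested in a functional assay on HeLa cells (Homo sapiens) for antiproliferative activity, read by MTT assay, with a stated time of 72 h; a lower number here means a stronger inhibitor, a higher number a weaker inhibitor. In this assay compound 1 gives > 100000 nM, which is a limit of the assay rather than a number. Compound 2 `Cc1c(CC(O)COCc2ccccc2)[nH]c(=O)[nH]c1=O` differs from it by methyl in place of hydrogen on an aromatic carbon. In this assay compound 2 gives > 100000 nM, again only a limit. The step that the two limits leave unreadable from compound 1 to compound 2 therefore cannot be read. Compound 3 `C[Si](C)(C)CCOCn1c(CC(O)CO)cc(=O)[nH]c1=O` has a core whose difference from compound 1 is not broken down here. In this assay compound 3 gives > 100000 nM, also a limit. Compound 4 `Cc1c(CC(O)CO)n(COCC[Si](C)(C)C)c(=O)[nH]c1=O`, not yet measured, differs from compound 3 by methyl in place of hydrogen on an aromatic carbon. This is the same kind of change as from compound 1 to compound 2, but here the place is ortho to a 2,3-dihydroxypropyl group and meta to a group of 8 heavy atoms, where before it was ortho to a large group. Because (the limit of > 100000 nM in this assay, at which 3 of the 3 values shown sit), the step of a number no higher from compound 3 to compound 4 (the limit leaves the size open) is expected to be small. Compound 4 is therefore estimated at 100000 nM, most likely again only a limit.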

Compound 4, half-maximal inhibitory concentration: > 100000 nM
Compound 4 gave a limit, no number (the forecaster's own chance of this, stated with the estimate: 90%); the middle value lies on the limit itself.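

Going by these compounds alone, compound 3 and compound 4 both give only a limit, so the methyl step between them cannot be read, any more than the one between compound 1 and compound 2. The compounds shown leave open how active any of them is in this assay, and whether adding the methyl changes that activity at all.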